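Replacing fluoro with iodo on compound 2

This account rests on a few compounds, and the source may have more. Where it says the series, first, only, none or still open, it means among the compounds named here.

In an ADME assay on L929 cells (Mus musculus) for cytotoxicity, read by resazurin assay, with a stated time of 96 h (a higher number here means that more compound is tolerated, a lower number that less compound is tolerated), compound 2 (`NC(=S)N/N=C(\COc1ccc(F)cc1)c1ccc(Br)cc1`) gives 52300 nM. In this assay, compound 3 (`NC(=S)N/N=C(\COc1ccc(F)c(Cl)c1)c1ccc(Br)cc1`) gives 48000 nM, and the step of a 1.1-fold lower number from compound 2 to compound 3 (0.04 log units; within the scatter) leaves the two compounds level. In this assay, compound 1 (`CCc1ccc(OC/C(=N\NC(N)=S)c2ccc(Br)cc2)cc1`) gives only a limit, < 25500 nM.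

Compound 4 (`NC(=S)N/N=C(\COc1ccc(I)cc1)c1ccc(Br)cc1`) carries iodo in place of fluoro on an aromatic carbon. Among the compounds with values here, two measured steps bear on this. Adding chloro gave the step above, which stays within the scatter. Fluoro in place of ethyl gave an at least 2.0-fold higher number from compound 1 to compound 2 (0.31 log units; beyond the scatter), the only step that changes the fluoro position. Taking fluoro away again is therefore expected to give a modest fall, not a rise. The estimated step is a 2.0-fold lower number from compound 2 to compound 4 (0.30 log units; within the scatter). Compound 4 is expected at 26000 nM, with an estimated range of 11000 nM to 55000 nM.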

Compound 4, half-maximal cytotoxic concentration: < 20400 nM
Compound 4: a limit, no number; the forecaster's own chance of this, stated with the estimate: 30%; middle value at least 1.2-fold (0.10 log units) from the limit.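

In this assay, the change from 4-fluorophenyl to 4-iodophenyl gives an at least 2.5-fold lower number from compound 2 to compound 4 (0.40 log units; beyond the scatter), so iodo, like ethyl before it, sits on the lower side of fluoro at this position. Compound 4 and compound 1 each give a limit and not a number, so the step between them cannot be read. Only compound 2 and compound 3, which keep fluoro here, give numbers. As far as these compounds go, how far compound 4 lies under its limit stays open. From the compounds shown here alone, whether an amine or a carboxylic acid at this position would match compound 2 also remains open.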